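Adding a 4-methoxybenzyl group to compound 2

This account rests on a few compounds, and the source may have more. Where it says the series, first, only, none or still open, it means among the compounds named here.

In a functional assay on MDA-MB-231 cells (Homo sapiens) for cytotoxicity, read by MTT assay, with a stated time of 24 h (on this read-out lower numbers stand for stronger inhibition and higher numbers for weaker inhibition), compound 1 (`COc1ccc2c(c1)cc(-c1cc(OC)c(OC)c(OC)c1)n2Cc1ccc(OCc2ccccc2)cc1`) gives > 30000 nM as a limit and not a number. From the compounds shown here alone, compound 2 (`COc1ccc(Cn2c(-c3cc(OC)c(OC)c(OC)c3)cc3cc(OC)ccc32)cc1`) gives > 30000 nM as a limit too, so its exact standing is unknown. So far the evidence is the limit of > 30000 nM in this assay, at which 2 of the 2 values shown sit, without exception. For the measured compounds named here, the one measured step (a step that the two limits leave unreadable from compound 1 to compound 2) offers no size to build on.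

Compound 3 (`COc1ccc(Cc2c(-c3cc(OC)c(OC)c(OC)c3)n(Cc3ccc(OC)cc3)c3ccc(OC)cc23)cc1`) differs from compound 2 by 4-methoxybenzyl in place of hydrogen on an aromatic carbon with 4-methoxybenzyl in place of hydrogen on an aromatic carbon, next to the ring atom that bears a 3,4,5-trimethoxyphenyl group.

With no readable step to lean on, no change beyond the scatter is expected in this assay and no direction can be claimed. The expected move is a number no higher from compound 2 to compound 3 (the limit leaves the size open) in this estimate. For compound 3 the estimate is 30000 nM with an expected range from 10000 nM to 60000 nM and a good chance of another limit.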

Compound 3, half-maximal inhibitory concentration: > 30000 nM
Compound 3: no number, only a limit (the forecaster's own chance of this, stated with the estimate: 75%); the middle value sits exactly at the limit.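

In this assay compound 3 gives > 30000 nM, a limit and not a number. With compound 2 and compound 3 both given only as limits, the step between them cannot be read. The compounds shown leave open how far each one's true value lies from that limit, and whether 4-methoxybenzyl in this place changes the read-out at all.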